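This account rests on a few compounds, and the source may have more. Where it says the series, first, only, none or still open, it means among the compounds named here.

Compound 1 `CC1CCN(c2c(S(=O)(=O)c3cccc(Cl)c3)cnc3cc(Cl)ccc23)CC1` is one of three measured members of the series. In an assay on isolated protein for displacement of a labelled ligand from metabotropic glutamate receptor 5 (Homo sapiens), with a stated time of 60 min, tested at 1 uM (a lower number here means less inhibition, a higher number more inhibition at the concentration tested (going by the name of the read-out)), compound 1 gives 92%; compound 2 `CC1CCN(c2c(S(=O)(=O)c3ccc(F)c(Cl)c3)cnc3cc(F)ccc23)CC1` gives 94% and compound 3 `CC1CCN(c2c(S(=O)(=O)c3cc(Cl)cc(Cl)c3)cnc3cc(F)ccc23)CC1` gives 87%, so the three numbers lie within the usual scatter of one another and no ranking among them is supported. Going by the values given here, the only single-point step measured, a number 7 percentage points lower from compound 2 to compound 3 (within the scatter), exchanges the substitution pattern of the aryl group on the sulfonyl sulfur and stays within the scatter.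

Compound 4 `COc1cccc(S(=O)(=O)c2cnc3cc(Cl)ccc3c2N2CCC(C)CC2)c1` differs from compound 1 by methoxy in place of chloro on an aromatic carbon, on an aromatic carbon of a six-membered aromatic ring of carbon only, meta to a large group. Among the compounds with values here, the same ring was varied in the step from compound 2 to compound 3 without an effect beyond the scatter, which is the nearest evidence; no measured step replaces a halogen by methoxy. The expectation is therefore no change beyond the scatter, with a number 7 percentage points lower from compound 1 to compound 4 (within the scatter) as the estimated step from compound 1. Compound 4 is expected to give 85% in this assay, in the range 65% to 97%.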

Compound 4, a percentage reported as inhibition, at one concentration (the size of the read-out at that concentration, not a potency): 93%
Estimate against measurement, compound 4: 8 percentage points below; low and high end bracket the measured number.
By their numbers in this assay, from the lowest: compounds 3, 1, 4 and 2 (each within the scatter of the next).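

In this assay, going by these compounds alone, the exchange of 3-chlorophenyl for 3-methoxyphenyl gives a number 1 percentage points higher from compound 1 to compound 4 (within the scatter), and this is the first measured case of a non-halogen group at this place, since the earlier step only exchanged one halogen pattern for another. Chlorine on an aromatic carbon, meta to a large group, is therefore not needed to hold the read-out at the level of compound 1, at least at this single concentration. Nothing available explains this result.

A read-out at one concentration gives no potency, so any difference between compound 1 and compound 4 in potency stays hidden. Also open, from the compounds shown here alone, is whether an amine, a carboxylic acid or a longer chain such as ethoxy at this place would keep the read-out within the scatter.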